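The source may hold more compounds than are shown below. What is called first, only, known or untested is meant among the compounds shown, and "the series" means these compounds.

Measured compounds:
Compound 1 `O=C(NCc1cc(Cl)ccc1-n1cnnn1)[C@@H]1C[C@@H]2C[C@@H]2N1C(=O)[C@H](O)Cc1ccccn1` gives 1000 nM in a functional assay on a cell-free system (plasma, Homo sapiens), with a stated time of 3 min; a lower number here means a stronger inhibitor, a higher number a weaker inhibitor.
Compound 2 `CC(C)(C)C[C@@H](O)C(=O)N1[C@@H]2C[C@@H]2C[C@H]1C(=O)NCc1cc(Cl)ccc1-n1cnnn1` gives 520 nM in this assay.
Compound 3 `CC(C)(C)C[C@@H](O)C(=O)N1[C@H](C(=O)NCc2cc(Cl)ccc2-n2cnnn2)C[C@@H]2C[C@@H]21` gives 570 nM in this assay.

Compound 2 has the lowest of the three numbers shown, but its distances to compound 3 and to compound 1 are both within the scatter, so the three compounds cannot be separated on these numbers.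

Compound 4 `CC1(C[C@@H](O)C(=O)N2[C@@H]3C[C@@H]3C[C@H]2C(=O)NCc2cc(Cl)ccc2-n2cnnn2)CC1` is not yet measured. It differs from compound 2 in one place: 1-methylcyclopropyl in place of tert-butyl on a saturated chain carbon, two bonds along the chain from a carbonyl carbon and an oxygen on a saturated carbon.

Two measured steps help to judge this. From compound 1 to compound 3 a tert-butyl took the place of a pyridin-2-yl at the same position, and the result was a 1.8-fold lower number from compound 1 to compound 3 (0.24 log units; within the scatter). From compound 2 to compound 3 only the configuration changed, (the fact that compounds 2 and 3 differ only in the configuration as drawn), and the result was a 1.1-fold higher number from compound 2 to compound 3 (0.04 log units; within the scatter). Neither step reached beyond the scatter, and neither is the same exchange as tert-butyl to 1-methylcyclopropyl, so no step beyond the scatter is expected in this assay in either direction. Compound 4 is therefore expected to give about 500 nM, within a range of 250 nM to 1000 nM, which means an expected step of a 1.0-fold lower number from compound 2 to compound 4 (0.02 log units; within the scatter).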

Compound 4, half-maximal inhibitory concentration: 1300 nM
Beside the measured number, compound 4's estimate is 2.6-fold (0.41 log units) below it; measured number outside the range, above it.
By their numbers in this assay, from the lowest: compounds 2, 3, 1 and 4 (each within the scatter of the next, the first and the last beyond it).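

In this assay, the group on the saturated chain carbon, two bonds along the chain from a carbonyl carbon and an oxygen on a saturated carbon, can matter even when the change is small: replacing tert-butyl with 1-methylcyclopropyl gives a 2.5-fold higher number from compound 2 to compound 4 (0.40 log units; beyond the scatter) and is the only step shown at this position that lies beyond the scatter. The two groups have the same count of heavy atoms, all carbon, and neither has hydrogen-bond donors or acceptors, but the entering group carries a three-membered ring. Nothing measured here gives a reason for this step.

The compounds shown leave open how a cyclobutyl group, a longer carbon chain or an amine would read at this position. From the compounds shown here alone, it also remains open whether the same exchange made on compound 3 would give a similar step.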